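This account rests on a few compounds, and the source may have more. Where it says the series, first, only, none or still open, it means among the compounds named here.

Measured so far in a functional assay on PC-3 cells (Homo sapiens) for cytotoxicity, with a stated time of 48 h; a lower number here means a stronger inhibitor, a higher number a weaker inhibitor
compound 1 `COc1cc(OC)c(C(=O)/C=C/c2ccccc2OC)c(OC)c1` gives 8100 nM
compound 2 `COc1cccc(/C=C/C(=O)c2c(OC)cc(OC)cc2OC)c1` gives 3100 nM
compound 3 `COc1cc(O)c(C(=O)/C=C/c2ccccc2OC)c(OC)c1` gives 9600 nM

Compound 2 holds the lowest number of the three. Next comes compound 4 `COc1cc(OC)c(C(=O)/C=C/c2ccc(F)cc2)c(OC)c1` with 4-fluorophenyl in place of 3-methoxyphenyl on a double-bonded chain carbon bound to a double-bonded chain carbon and no measured compound carries that group. The closest evidence is the modest step of a 2.6-fold lower number from compound 1 to compound 2 (0.42 log units; beyond the scatter) at the same place, which shows compound 2 gaining from its 3-methoxyphenyl. The step of a 1.2-fold higher number from compound 1 to compound 3 (0.07 log units; within the scatter) lies within the scatter and at a different place, so it adds little. In this assay a higher number is therefore expected, the estimated change being a 1.9-fold higher number from compound 2 to compound 4 (0.29 log units; within the scatter) and of similar size to that modest step. For compound 4 the estimated value is 6000 nM (expected range 2200 nM to 16000 nM).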

Compound 4, half-maximal inhibitory concentration: 5500 nM
Beside the measured number, compound 4's estimate is 1.1-fold (0.04 log units) above it, within the range that was stated.
By their numbers in this assay, from the lowest: compounds 2, 4, 1 and 3 (each within the scatter of the next, the first and the last beyond it).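

In this assay, 4-fluorophenyl carries fluorine and no oxygen at this place, yet a 1.8-fold higher number from compound 2 to compound 4 (0.25 log units; within the scatter) leaves it unresolved from 3-methoxyphenyl. It is equally unresolved from 2-methoxyphenyl, with a 1.5-fold lower number from compound 1 to compound 4 (0.17 log units; within the scatter), although the two methoxyphenyl groups stand apart, with a 2.6-fold lower number from compound 1 to compound 2 (0.42 log units; beyond the scatter). Nothing available explains these numbers.

Going by these compounds, whether an amine or a carboxylic acid on the phenyl ring at this place would move the number beyond the scatter remains open. Also open, on these data alone, is whether 4-fluorophenyl would keep this standing on the core of compound 3.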